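This account rests on a few compounds, and the source may have more. Where it says the series, first, only, none or still open, it means among the compounds named here.

Measured compounds in the series:

compound 1, `CCCCCCCCCNC(=O)[C@H]1OC(n2cnc3c(N)ncnc32)[C@H](O)[C@@H]1O`, 31 nM in an assay on cell membranes for binding affinity to 2-oxoglutarate receptor 1 (Rattus norvegicus), read by radioligand binding; a higher number here means a weaker inhibitor, a lower number a stronger inhibitor
compound 2, `Nc1ncnc2c1ncn2C1O[C@H](C(=O)NC2CCCCCCC2)[C@@H](O)[C@H]1O`, 23 nM in this assay

Compound 2 carries the lowest of the two numbers, but the step of a 1.3-fold lower number from compound 1 to compound 2 (0.13 log units; within the scatter) lies within the scatter, so the two measured compounds cannot be told apart on this readout. Compound 3, `CC1CCCCC1NC(=O)[C@H]1OC(n2cnc3c(N)ncnc32)[C@H](O)[C@@H]1O`, has not yet been measured. It differs from compound 2 by 2-methylcyclohexyl in place of cyclooctyl on an amide-type nitrogen. Among the compounds with values here, only one measured step touches the same position, the exchange from compound 1 to compound 2, which swapped nonyl for cyclooctyl and gave a 1.3-fold lower number from compound 1 to compound 2 (0.13 log units; within the scatter), a change within the scatter. That step shows the group on the amide-type nitrogen tolerates a change of shape between an open chain and an eight-membered ring without a measurable shift. Compound 3 brings a smaller ring with a methyl branch, a change of a different kind from the one measured, so the expectation rests on a single step and is wide. On that basis compound 3 is expected to stay close to compound 2, with a 1.7-fold higher number from compound 2 to compound 3 (0.24 log units; within the scatter), most likely no shift beyond the scatter. The estimate for compound 3 in this assay is 40 nM, within a range of 15 nM to 110 nM.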

Compound 3, inhibition constant: 69.5 nM
Compound 3: middle estimate off by 1.7-fold (0.24 log units), on the low side; the range from low to high includes it.
By their numbers in this assay, from the lowest: compounds 2 and 1 (each within the scatter of the next); then compound 3.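

In this assay, within the data shown here, the exchange of cyclooctyl for 2-methylcyclohexyl on the amide-type nitrogen gives a 3.0-fold higher number from compound 2 to compound 3 (0.48 log units; beyond the scatter) and the exchange of nonyl for the same group gives a 2.2-fold higher number from compound 1 to compound 3 (0.35 log units; beyond the scatter) as the first steps at this position to pass beyond the scatter. The position is therefore not indifferent to every carbon-only group, and the tolerance seen between the open nonyl chain and the eight-membered ring does not carry over to this branched six-membered ring, although both shifts remain modest. No available data explain the shift.

The 2-methylcyclohexyl group differs from cyclooctyl in both ring size and the presence of a methyl branch, so the compounds shown cannot assign the shift to either feature, a question that plain cyclohexyl on the same nitrogen would address. Also open is how this position responds to a hydroxyl or an amine on the ring, or to a chain longer than nonyl, since all three groups shown consist of carbon only.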